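The source may hold more compounds than are shown below. What is called first, only, known or untested is meant among the compounds shown, and "the series" means these compounds.

Compound 1 `CCSCCn1c(N2CCN(C)CC2)nc2ccccc21` was examined in a functional assay on ileum for inhibition of histamine H1 receptor (Cavia porcellus) (on this read-out higher numbers stand for weaker inhibition and lower numbers for stronger inhibition), where compound 1 gives 19 nM. Among the compounds with values here, the only other measured compound, compound 2 `CCCN1CCN(c2nc3ccccc3n2CCOCC)CC1`, differs from compound 1 in more than one place, and in this assay compound 2 gives 16 nM. The two values lie within the scatter of each other, so no difference between them can be read; compound 1 simply stands at one of two closely matching numbers.

Compound 3 `CN1CCN(c2nc3ccccc3n2-c2ccccc2)CC1` has not yet been measured in this assay. It differs from compound 1 in a single place: phenyl in place of 2-(ethylsulfanyl)ethyl on an aromatic nitrogen. Within the data shown here, nothing among the measured pairs shows what such a change does here, since no two measured compounds differ in one place only. With two measured numbers that agree within the scatter, there is no trend to extend. The expectation is therefore a cautious one: the step from compound 1 to compound 3 is estimated at a 2.6-fold higher number from compound 1 to compound 3 (0.42 log units; beyond the scatter), a move toward weaker inhibition of modest size, with a range wide enough to include no change at all. On that basis compound 3 is expected to give about 50 nM in this assay, estimated between 10 nM and 250 nM.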

Compound 3, half-maximal inhibitory concentration: 760 nM
Compound 3: the middle estimate sits 15-fold (1.18 log units) below what was measured; measured number outside the range, above it.
By their numbers in this assay, from the lowest: compounds 2 and 1 (each within the scatter of the next); then compound 3.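

In this assay, within the data shown here, the group on the aromatic nitrogen proves to matter a great deal: phenyl in place of 2-(ethylsulfanyl)ethyl gives a 40-fold higher number from compound 1 to compound 3 (1.60 log units; beyond the scatter), a large move toward weaker inhibition and the first change at a single place that can be read. The step exchanges a chain with no ring, carrying one sulfur atom, for a six-membered aromatic ring of carbon only, so the position that showed nothing before now proves far from indifferent to what it carries. Nothing measured here explains why the step is so large.

Among these compounds, the single step cannot separate the arrival of the ring from the departure of the chain, and a benzyl group or a plain ethyl chain on the same nitrogen would bear on which of the two counts, as would a 2-(dimethylamino)ethyl chain with an amine at its end. From the compounds shown here alone, it also remains open whether a step of this size would hold if a piperidine stood in place of the 4-methylpiperazin-1-yl group.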